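The source may report more compounds than this note shows. Statements on the series, on what has been measured and on what is new or still open speak of the compounds shown alone.

Going by the values given here, in a physicochemical assay for lipophilicity, at pH 7.4 (on this read-out lower numbers stand for lower lipophilicity and higher numbers for higher lipophilicity), compound 1 `CCc1ccc(N(C2COC2)S(=O)(=O)c2ccc3c(c2)C(O)CC(C2CCOCC2)O3)cc1` gives 2.63, the higher of the two numbers so far. Compound 2 `CCc1ccc(N(CC(C)C)S(=O)(=O)c2ccc3c(c2)C(O)CC(C2CCNCC2)O3)cc1` gives 1.04, lower by more than the usual scatter. Compound 3 `CCc1ccc(NS(=O)(=O)c2ccc3c(c2)C(O)CC(C2CCOCC2)O3)cc1` keeps the core of compound 1 and changes in one place: hydrogen in place of oxetan-3-yl on a sulfonamide nitrogen. Among the compounds with values here, no measured pair shows this change alone, so the expectation is rough. The expected step is slightly downward and no larger than the scatter, estimated as a number 0.13 log units lower from compound 1 to compound 3 (within the scatter). For compound 3 the estimated value is 2.5, with a range from 2 to 3.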

Compound 3, distribution coefficient: 2.59
The estimate for compound 3 lay 0.09 log units below the measured number; the range from low to high includes it.
By their numbers in this assay, from the lowest: compound 2; then compounds 3 and 1 (each within the scatter of the next).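

On a sulfonamide nitrogen, putting hydrogen in place of oxetan-3-yl removes a whole four-membered ring, yet this assay shows a number 0.04 log units lower from compound 1 to compound 3 (within the scatter) and so cannot tell these two compounds apart. Going by these compounds alone, this is the first comparison at this position that involves a change in one place alone. Nothing available explains this result. Compound 2 differs from compound 1 in more than one place, so it cannot add to this comparison. Still open, going by these compounds, is whether an ethyl chain, or a chain carrying an amine or a carboxylic acid, on this nitrogen would stay as close to compound 1.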